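The source may report more compounds than this note shows. Statements on the series, on what has been measured and on what is new or still open speak of the compounds shown alone.

Values in a functional assay on MCF7 cells (Homo sapiens) for cytotoxicity, read by WST assay, with a stated time of 72 h; a higher number here means a weaker inhibitor, a lower number a stronger inhibitor:
compound 1 `O=C1Nc2c(ccc(F)c2F)C1(c1ccc(O)cc1)c1ccc(F)cc1`: 2.6 nM
compound 2 `Cc1ccc(C2(c3ccc(O)cc3)C(=O)Nc3c2ccc(F)c3F)cc1`: 1.7 nM
compound 3 `CCCOc1ccc(C2(c3ccc(O)cc3)C(=O)Nc3c2ccc(F)c3F)cc1`: 356 nM

Compound 1 stands at the low end of these numbers together with compound 2 (a 1.5-fold lower number from compound 1 to compound 2 (0.18 log units; within the scatter)). Compound 4 `CCCCCOc1ccc(C2(c3ccc(O)cc3)C(=O)Nc3c2ccc(F)c3F)cc1` carries pentyloxy in place of fluoro on an aromatic carbon, para to a large group: pentyloxy in place of fluoro on an aromatic carbon. The closest measured change is propoxy in place of fluoro, and it was large (a 140-fold higher number from compound 1 to compound 3 (2.14 log units; beyond the scatter)). Propoxy in place of methyl was also large (a 210-fold higher number from compound 2 to compound 3 (2.32 log units; beyond the scatter)). On these data alone, no chain of this length has been measured, so the further effect of the longer chain remains open. A large upward step in this assay is expected, somewhat beyond the step to compound 3: a 350-fold higher number from compound 1 to compound 4 (2.54 log units; beyond the scatter). For compound 4 the estimated value is 900 nM, with an expected range of 250 nM to 3500 nM.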

Compound 4, half-maximal inhibitory concentration: > 1000 nM
Compound 4 was reported as a limit (the forecaster's own chance of this, stated with the estimate: 10%); middle value at least 1.1-fold (0.04 log units) away from the limit.
By their numbers in this assay, from the lowest: compounds 2 and 1 (each within the scatter of the next); then compound 3. At a limit, above all of these: compound 4.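

Compound 4 is reported only as a limit in this assay: the limit of > 1000 nM in this assay, at which 1 of the 4 values shown sits.
Going from propoxy to pentyloxy at this aromatic carbon still raises the number (an at least 2.8-fold higher number from compound 3 to compound 4 (0.44 log units; beyond the scatter)), so the rise seen with propoxy does not stop at that chain length.
Against the two small groups the change stays large (an at least 380-fold higher number from compound 1 to compound 4 (2.58 log units; beyond the scatter); an at least 580-fold higher number from compound 2 to compound 4 (2.76 log units; beyond the scatter)).

On these data alone, how far the number for compound 4 lies beyond its limit stays open.
So does the point between methyl and propoxy where the rise begins, and whether methoxy, ethoxy or an amine at this position keeps the number low.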